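The source may report more compounds than this note shows. Statements on the series, on what has been measured and on what is new or still open speak of the compounds shown alone.

For the measured compounds named here, compound 2 `CCn1cc(C(CC)(CC)c2ccc(C#CC(O)(CC)CC)c(C)c2)cc1C(=O)OCCO` gives the lowest of the two numbers so far in a functional assay on MCF7 cells (Homo sapiens) for antiproliferative activity, read by MTT assay, with a stated time of 72 h (on this read-out higher numbers stand for weaker inhibition and lower numbers for stronger inhibition), with 1880 nM; its nearest neighbour, compound 1 `CCn1cc(C(CC)(CC)c2ccc(C#CC(O)(CC)CC)c(C)c2)cc1C(=O)NCCCN(C)C`, gives 20200 nM. Compound 3 `CCn1cc(C(CC)(CC)c2ccc(C#CC(O)(CC)CC)c(C)c2)cc1C(=O)N[C@@H](C(=O)O)C(C)C` differs from compound 2 by (1-carboxy-2-methylpropyl)amino in place of 2-hydroxyethoxy on a carbonyl carbon. Going by the values given here, the only measured step at this carbonyl carbon, an 11-fold lower number from compound 1 to compound 2 (1.03 log units; beyond the scatter), exchanged two quite different groups, so it bears on the new change only in showing that the group on this carbonyl carbon can shift the number by a large step. With an amide returning in compound 3, a higher number than for compound 2 is expected, a 3.2-fold higher number from compound 2 to compound 3 (0.50 log units; beyond the scatter). The estimate for compound 3 is 6000 nM, with a range of 1500 nM to 25000 nM.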

Compound 3, half-maximal inhibitory concentration: 18000 nM
Compound 3: the middle estimate sits 3.0-fold (0.48 log units) below what was measured; low and high end bracket the measured number.
By their numbers in this assay, from the lowest: compound 2; then compounds 3 and 1 (each within the scatter of the next).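

In this assay, compound 2 stays apart from both amides: a 9.6-fold higher number from compound 2 to compound 3 (0.98 log units; beyond the scatter), with (1-carboxy-2-methylpropyl)amino in place of 2-hydroxyethoxy on the carbonyl carbon. Between the amides, 1-carboxy-2-methylpropyl in place of 3-(dimethylamino)propyl on the amide-type nitrogen gives a 1.1-fold lower number from compound 1 to compound 3 (0.05 log units; within the scatter), so these two substituents do not separate on this read-out. No measurement shown here accounts for these numbers.

Still open, as far as these compounds go, is whether the low number of compound 2 follows the ester link or its 2-hydroxyethyl group. A 2-hydroxyethyl amide, or a methyl ester, at this carbonyl carbon would separate the two.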